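A few compounds are considered here, and "the series" means these few. Any claim that something is new, unique, unknown or untested is made for them only; others in the source may bear on it.

In an ADME assay on MT4 cells (Homo sapiens) for cytotoxicity, read by MTT assay, with a stated time of 4 days (a higher number here means that more compound is tolerated, a lower number that less compound is tolerated), compound 1 `Cc1cc(C#N)cc(C)c1Oc1ccnc(S(=O)(=O)CC(=O)Nc2ccccc2F)n1` gives 28400 nM, compound 2 `Cc1cc(C#N)cc(C)c1Oc1ccnc(S(=O)(=O)CC(=O)Nc2cccc(F)c2)n1` gives 25900 nM, and compound 3 `Cc1cc(C#N)cc(C)c1Oc1ccnc(S(=O)(=O)CC(=O)Nc2ccccc2Cl)n1` gives 12500 nM, the lowest of the three. Compound 4 `Cc1cc(C#N)cc(C)c1Oc1ccnc(S(=O)(=O)CC(=O)Nc2ccc(C#N)cc2F)n1` carries 4-cyano-2-fluorophenyl in place of 2-chlorophenyl on an amide-type nitrogen. Among the measured steps, chloro in place of fluoro gave a 2.3-fold lower number from compound 1 to compound 3 (0.36 log units; beyond the scatter), and 2-chlorophenyl in place of 3-fluorophenyl gave a 2.1-fold lower number from compound 2 to compound 3 (0.32 log units; beyond the scatter), both modest. Moving the fluoro gave a 1.1-fold lower number from compound 1 to compound 2 (0.04 log units; within the scatter). Compound 4 has fluoro again, so the chloro steps, read backwards, suggest a small rise. Going by the values given here, no measured compound has a 4-cyano-2-fluorophenyl group, so the data leave the added cyano untested. The expected change is a 1.8-fold higher number from compound 3 to compound 4 (0.25 log units; within the scatter). For compound 4 the estimated value is 22000 nM, with an expected range from 8000 nM to 60000 nM.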

Compound 4, half-maximal cytotoxic concentration: > 268000 nM
Compound 4: a limit, no number; the forecaster's own chance of this, stated with the estimate: 15%; at least 12-fold (1.08 log units) between middle value and limit.
By their numbers in this assay, from the lowest: compound 3; then compounds 2 and 1 (each within the scatter of the next). At a limit, above all of these: compound 4.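

In this assay, compound 4 gives a limit, not a number: the limit of > 268000 nM in this assay, at which 1 of the 4 values shown sits. Swaps among fluoro and chloro on the phenyl group had moved the number only modestly, yet 4-cyano-2-fluorophenyl on the amide-type nitrogen gives an at least 21-fold higher number from compound 3 to compound 4 (1.33 log units; beyond the scatter) and an at least 10-fold higher number from compound 2 to compound 4 (1.01 log units; beyond the scatter). Cyano in place of hydrogen on an aromatic carbon, the only single added group here, gives an at least 9.4-fold higher number from compound 1 to compound 4 (0.97 log units; beyond the scatter), so this one addition can shift tolerance far more than the halogen swaps did.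

From the compounds shown here alone, how far compound 4 lies past its limit stays open. So does whether an amine or a carboxylic acid in place of the cyano would do the same.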